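This account rests on a few compounds, and the source may have more. Where it says the series, first, only, none or still open, it means among the compounds named here.

Measured so far in a functional assay on Jurkat E6.1 cells (Homo sapiens) for cytotoxicity, read by MTT assay, with a stated time of 24 h; on this read-out higher numbers stand for weaker inhibition and lower numbers for stronger inhibition:
compound 1 `COC(=O)/C(=C\c1ccc(OC(=O)c2ccc(OC)cc2)cc1)Sc1ccnc2cc(Cl)ccc12` gives 11000 nM;
compound 2 `COC(=O)/C(=C\c1ccc(OC(=O)c2ccccc2OC)cc1)Sc1ccnc2cc(Cl)ccc12` gives 44700 nM.

Compound 2 stands highest of the two numbers in this assay; the nearest is compound 1, and the step of a 4.1-fold higher number from compound 1 to compound 2 (0.61 log units; beyond the scatter) lies beyond the scatter. Compound 3 `COC(=O)/C(=C\c1ccc(OC(=O)c2cc(OC)cc(OC)c2)cc1)Sc1ccnc2cc(Cl)ccc12` is not yet measured. It differs from compound 2 by 3,5-dimethoxyphenyl in place of 2-methoxyphenyl on a carbonyl carbon. Going by the values given here, the only measured step that bears on this place is a 4.1-fold higher number from compound 1 to compound 2 (0.61 log units; beyond the scatter), which shows that where the methoxy sits on this ring moves the number by a modest amount. Compound 3 carries the 3,5-dimethoxyphenyl, a pattern not yet measured in this assay, so the step from compound 1 to compound 2 gives no firm direction for it. The number for compound 3 is expected to fall between the two measured values, with the step of a 2.2-fold lower number from compound 2 to compound 3 (0.35 log units; beyond the scatter) expected to be modest. Compound 3 is therefore estimated at 20000 nM, within 7000 nM to 60000 nM.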

Compound 3, half-maximal inhibitory concentration: 28900 nM
For compound 3 the middle estimate is 1.4-fold (0.16 log units) below the measured one; low and high end bracket the measured number.
By their numbers in this assay, from the lowest: compound 1; then compounds 3 and 2 (each within the scatter of the next).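

In this assay the 3,5-dimethoxyphenyl and the 2-methoxyphenyl cannot be told apart on this carbonyl carbon: a 1.5-fold lower number from compound 2 to compound 3 (0.19 log units; within the scatter) is the whole difference, so the extra methoxy group in compound 3 brings no readable change. With a 2.6-fold higher number from compound 1 to compound 3 (0.42 log units; beyond the scatter) as the second step, compound 1 with its 4-methoxyphenyl now stands apart from two other methoxy patterns instead of one, and it is the most potent of the three, since its steps to both others lie beyond the scatter. Nothing at hand accounts for this gap.

On these data alone, whether the 4-methoxyphenyl advantage depends on the methoxy group itself stays open, and a hydroxyl group, an amine or a longer alkoxy chain at the same place on the ring would test it. As far as these compounds go, all three numbers also sit in one cell read-out, so how far the order carries beyond it remains unknown.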